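From Thiophen-2-yl to Phenyl at the Assay Limit

The compounds below may be only part of what the source reports. "The series", "measured", "known", "first", "only" and "open" are said of these compounds alone.

Compound 1 `CSc1ncnc2c1c(-c1ccccc1)cn2[C@@H]1O[C@H](CO)[C@@H](O)[C@H]1O` and compound 2 `CNc1ncnc2c1c(-c1cccs1)cn2[C@@H]1O[C@H](CO)[C@@H](O)[C@H]1O` have both been tested in a functional assay on CEM-DNR-bulk cells (Homo sapiens), read by MTT assay, with a stated time of 72 h; on this read-out higher numbers stand for weaker inhibition and lower numbers for stronger inhibition. Compound 1 gives > 20000 nM, which is a limit of the assay and not a number. Compound 2 gives > 20000 nM, which is also a limit. Compound 2 therefore has no exact value, and no size of difference can be read between these two compounds.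

Compound 3 `CNc1ncnc2c1c(-c1ccccc1)cn2[C@@H]1O[C@H](CO)[C@@H](O)[C@H]1O` differs from compound 2 in one place, with phenyl in place of thiophen-2-yl on an aromatic carbon. A five-membered aromatic ring with one hetero atom leaves, and a six-membered aromatic ring of carbon only enters.

For the measured compounds named here, no measured pair yet shows what this exchange does. Compound 1 also carries a phenyl group, and compound 3 is expected to show no change beyond the usual scatter in this assay because of the limit of > 20000 nM in this assay, at which 2 of the 2 values shown sit. The expected step is a number no higher from compound 2 to compound 3 (the limit leaves the size open), with neither direction favoured. Compound 3 is estimated at 20000 nM, with an expected range of 8000 nM to 40000 nM, and the assay may well report only a limit again.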

Compound 3, half-maximal inhibitory concentration: > 20000 nM
Compound 3 ended at the assay's limit; the forecaster's own chance of this, stated with the estimate: 80%; the middle value sits exactly at the limit.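

In this assay, compound 3 gives > 20000 nM, which is a limit of the assay and not a number. No step can be read from compound 2 or compound 1 to compound 3: the limit of > 20000 nM in this assay, at which 3 of the 3 values shown sit.

The compounds shown leave open whether phenyl in place of thiophen-2-yl, or methylamino in place of methylsulfanyl, changes inhibition at all.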